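Replacing an aromatic amide with a cyclohexyl amide

This account rests on a few compounds, and the source may have more. Where it says the series, first, only, none or still open, it means among the compounds named here.

Measured compounds:
compound 1, `CCOC(=O)c1sc(-c2cccc(NC(=O)c3ccc(C(F)(F)F)cc3)c2)nc1Nc1ccc(N2CCN(C)CC2)cc1`, gives 33% in a functional assay on Raji cells (Homo sapiens) for antiproliferative activity, read by CCK-8 assay, with a stated time of 72 h, tested at 40 uM; on this read-out higher numbers stand for more inhibition at the one concentration tested (going by the name of the read-out) and lower numbers for less inhibition
compound 2, `CCOC(=O)c1sc(-c2cccc(NC(=O)c3ccc(F)c(Cl)c3)c2)nc1Nc1ccc(N2CCN(C)CC2)cc1`, gives 20.7% in this assay

Compound 2 stands lowest of the two numbers; its nearest neighbour is compound 1, and the step of a number 12.3 percentage points lower from compound 1 to compound 2 (beyond the scatter) lies beyond the scatter. Compound 3, `CCOC(=O)c1sc(-c2cccc(NC(=O)[C@H]3CC[C@H](C)CC3)c2)nc1Nc1ccc(N2CCN(C)CC2)cc1`, has not yet been measured in this assay. It differs from compound 2 by 4-methylcyclohexyl in place of 3-chloro-4-fluorophenyl on a carbonyl carbon. Among the compounds with values here, the only measured step, a number 12.3 percentage points lower from compound 1 to compound 2 (beyond the scatter), exchanges one aromatic group for another on the same carbonyl carbon and therefore bears only loosely on the move to a non-aromatic ring; no step with a 4-methylcyclohexyl group exists. Compound 3 is expected to fall near compound 2, with a step of a number 2.7 percentage points lower from compound 2 to compound 3 (within the scatter) that is estimated to remain within the scatter. The estimate for compound 3 in this assay is 18%, ranging from 5% to 33%.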

Compound 3, a percentage reported as inhibition, at one concentration (the size of the read-out at that concentration, not a potency): 26.1%
Beside the measured number, compound 3's estimate is 8.1 percentage points below it, and the stated range covers the measured number.
By their numbers in this assay, from the lowest: compounds 2, 3 and 1 (each within the scatter of the next, the first and the last beyond it).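

In this assay, within the data shown here, the carbonyl carbon of the amide carried a non-aromatic ring for the first time, and 4-methylcyclohexyl in place of 3-chloro-4-fluorophenyl gave a number 5.4 percentage points higher from compound 2 to compound 3 (within the scatter) while, measured against the other aromatic group, 4-methylcyclohexyl in place of 4-(trifluoromethyl)phenyl gave a number 6.9 percentage points lower from compound 1 to compound 3 (within the scatter) on the same read-out. An aromatic ring at this position was therefore not required to stay within the range set by compound 1 and compound 2, although those two aromatic compounds differ from each other beyond the scatter. No available evidence gives a cause for this result.

On these data alone, it remains open how a cyclopropyl ring, a piperidine ring or a straight butyl chain would read at this carbonyl carbon. Equally open, as far as these compounds go, is whether the other arrangement of the 2 defined stereocentres in the 4-methylcyclohexyl group would read the same.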